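From compound 2 to compound 3: a pyrazole exchange

The compounds below may be only part of what the source reports. "The series", "measured", "known", "first", "only" and "open" are said of these compounds alone.

Measured in an ADME assay on microsomes from liver (Homo sapiens) for metabolic stability, read by LC-MS, using NADPH, with stated times of 5 min and 30 min, tested at 1 uM; a lower number here means slower removal, a higher number faster removal of the compound:
Compound 1 `Cc1nc(CN(C)C)ccc1-c1cnc(NCc2c(F)ccc3c2CCO3)c2cn[nH]c(=O)c12`: 13 mL.min-1.g-1
Compound 2 `CNC(=O)c1cc(-c2cnc(NCc3c(F)ccc4c3CCO4)c3cn[nH]c(=O)c23)n(C)n1`: < 3 mL.min-1.g-1 (a limit)

Compound 2 reads < 3 mL.min-1.g-1, which is a limit of the assay and not a number. Compound 3 `Cc1nn(C)cc1-c1cnc(NCc2c(F)ccc3c2CCO3)c2cn[nH]c(=O)c12` carries 1,3-dimethyl-1H-pyrazol-4-yl in place of 1-methyl-3-(methylcarbamoyl)-1H-pyrazol-5-yl on an aromatic carbon. Going by the values given here, the one measured step bearing on this is an at least 4.3-fold lower number from compound 1 to compound 2 (0.63 log units; beyond the scatter), which also exchanged a group on an aromatic carbon and ended at the limit of < 3 mL.min-1.g-1 in this assay, at which 1 of the 2 values shown sits. In this assay a modest rise is expected, or none beyond the scatter, with compound 1 at 13 mL.min-1.g-1 as the measured reference. The expected step is an at least 1.6-fold higher number from compound 2 to compound 3 (0.22 log units; that floor lies within the scatter). For compound 3 the estimated value is 5 mL.min-1.g-1, with an expected range of 3 mL.min-1.g-1 to 10 mL.min-1.g-1.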

Compound 3, intrinsic clearance in microsomes: 27 mL.min-1.g-1
The estimate for compound 3 lay 5.4-fold (0.73 log units) below the measured number; the measured number lies above the stated range.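

In this assay, exchanging one pyrazole for another at this position gives an at least 9.0-fold higher number from compound 2 to compound 3 (0.95 log units; beyond the scatter), so a pyrazole ring alone does not keep the number low. The 1,3-dimethyl-1H-pyrazol-4-yl group also fares no better than the pyridine-bearing group of compound 1, with a 2.1-fold higher number from compound 1 to compound 3 (0.32 log units; beyond the scatter). Compound 2 stands at a limit of the assay, so the size of its step is only a floor: the limit of < 3 mL.min-1.g-1 in this assay, at which 1 of the 3 values shown sits.

The compounds shown leave open whether the methylcarbamoyl group or the ring's point of attachment carries the step. They also leave open how an amine or a carboxylic acid on the pyrazole would read.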